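Swapping a side chain for phenyl on the shared core

The source may report more compounds than this note shows. Statements on the series, on what has been measured and on what is new or still open speak of the compounds shown alone.

Compound 1 `CN(C)C(=O)c1cc2cnc(NC3CCCCC3)nc2n1C1CCCC1` gives 25000 nM
Compound 2 `CCC(CO)Nc1ncc2cc(C(=O)N(C)C)n(C3CCCC3)c2n1` gives 31000 nM

In a functional assay on MIA PaCa-2 cells (Homo sapiens) for inhibition, read by MTT assay (a lower number here means a stronger inhibitor, a higher number a weaker inhibitor), compound 2 gives 31000 nM and stands level with compound 1 within the scatter. Compound 3 `CN(C)C(=O)c1cc2cnc(Nc3ccccc3)nc2n1C1CCCC1` keeps the shared core but carries phenyl in place of 1-(hydroxymethyl)propyl on a nitrogen on an aromatic ring, and phenyl in place of 1-(hydroxymethyl)propyl on a nitrogen on an aromatic ring counts what changes. For the measured compounds named here, only one measured step touches this same place, namely a 1.2-fold higher number from compound 1 to compound 2 (0.09 log units; within the scatter) for a swap of cyclohexyl to 1-(hydroxymethyl)propyl. Going by the values given here, no measured compound carries phenyl, so this single small step is thin evidence for what the new group will do. Resting on that step, no change beyond the scatter is expected for compound 3 in this assay even though a wider range must be allowed. The estimated move is a 1.2-fold lower number from compound 2 to compound 3 (0.09 log units; within the scatter) and it remains only an expectation. For compound 3 the expected value is 25000 nM with an estimated range from 10000 nM to 55000 nM until the measurement arrives.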

Compound 3, half-maximal inhibitory concentration: 54900 nM
Compound 3: middle estimate off by 2.2-fold (0.34 log units), on the low side; measured number inside the range.
By their numbers in this assay, from the lowest: compounds 1, 2 and 3 (each within the scatter of the next, the first and the last beyond it).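

In this assay, replacing the open chain with an aromatic ring on this nitrogen gives a result within the scatter (a 1.8-fold higher number from compound 2 to compound 3 (0.25 log units; within the scatter)), so phenyl and 1-(hydroxymethyl)propyl cannot be told apart here, even though the chain has a hydrogen-bond donor and acceptor and phenyl has neither. For the compounds shown here, the comparison of phenyl with cyclohexyl is different (a 2.2-fold higher number from compound 1 to compound 3 (0.34 log units; beyond the scatter)): it is the first step at this position to clear the scatter, though only modestly, and it gives the position a small measurable difference between two ring groups. No supporting data are available to explain that difference between phenyl and cyclohexyl.

As far as these compounds go, it remains open whether a phenyl ring carrying a carboxylic acid, or a chain ending in an amine, would shift the number further at this nitrogen, or whether the values would stay in the same high range. From the compounds shown here alone, all three compounds differ only in this one place, so what the rest of the shared core contributes to the reading also remains open.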